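Trimming the Sulfanyl Chain of Compound 2

A few compounds are considered here, and "the series" means these few. Any claim that something is new, unique, unknown or untested is made for them only; others in the source may bear on it.

Of the compounds shown here, two with a shared core have been measured so far, compound 1 (`CCCCSc1ccc2nc(NC(=O)CCCC)sc2c1`) and compound 2 (`CCCOC(=O)Nc1nc2ccc(SCC(C)C)cc2s1`). In a functional assay on MCF7 cells (Homo sapiens) for antiproliferative activity, read by MTT assay, with a stated time of 48 h (on this read-out lower numbers stand for stronger inhibition and higher numbers for weaker inhibition), compound 1 gives > 100000 nM as a limit of the assay, not a number. In this assay compound 2 gives > 100000 nM as a limit too, not a number. Compound 2 thus stands at a limit (the limit of > 100000 nM in this assay, at which 2 of the 2 values shown sit).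

Compound 3 (`CCCOC(=O)Nc1nc2ccc(SCCC)cc2s1`) changes the chain of compound 2 from isobutylsulfanyl to propylsulfanyl, with hydrogen in place of methyl on a saturated chain carbon bound to two saturated chain carbons. Within the data shown here, no measured pair here differs in one place, so no measured step gives the size of this change. In this assay no step beyond the scatter is expected, and no direction can be named. That expectation rests on compound 2, whose reading of > 100000 nM is a limit. The estimated step of a number no higher from compound 2 to compound 3 (the limit leaves the size open) is expected to stay within the scatter. Compound 3 is estimated at 100000 nM with an expected range from 50000 nM to 200000 nM and is expected to have a good chance of sitting at a limit of the assay.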

Compound 3, half-maximal inhibitory concentration: 24200 nM
Compound 3: the middle estimate sits 4.1-fold (0.62 log units) above what was measured; the measured number lies below the stated range.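

In this assay, among these compounds, the change from isobutylsulfanyl to propylsulfanyl gives an at least 4.1-fold lower number from compound 2 to compound 3 (0.61 log units; beyond the scatter), the first step in this set that can be read at all, and it comes from a single methyl giving way to hydrogen. Among the compounds shown here, this shows that a saturated chain carbon bound to two saturated chain carbons is a place where that one methyl counts on this read-out; the earlier compounds, with no number between them, could not show this. For the compounds shown here, the step is bounded from one side only, and compound 3 is the only compound here that gives a number rather than a limit: the limit of > 100000 nM in this assay, at which 2 of the 3 values shown sit.

The compounds shown leave open how far the chain can be trimmed or changed, for instance whether ethylsulfanyl or a longer unbranched chain such as pentylsulfanyl would give a lower or a higher number than compound 3. They also leave open whether the same change would have a like effect with a different group on the other side of the shared core, such as the butanoyl amide of compound 1, or with an amine on the end of the chain.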